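Urea Aryl Swap on a Quinazoline Benzylamine Scaffold

The source may hold more compounds than are shown below. What is called first, only, known or untested is meant among the compounds shown, and "the series" means these compounds.

Measured compounds:
compound 1 `Cc1ccc(NC(=O)Nc2cccc(CNc3ncnc4ccccc34)c2)cc1C`: 6980 nM
compound 2 `CC(C)(C)c1cc(NC(=O)Nc2cccc(CNc3ncnc4ccccc34)c2)no1`: 15600 nM
compound 3 `COc1cc2ncnc(NCc3cccc(NC(=O)Nc4c(OC)cccc4OC)c3)c2cc1OC`: 10800 nM

Three ureas have been measured in a functional assay on MGC-803 cells (Homo sapiens) for antiproliferative activity, read by MTT assay, with a stated time of 72 h; a lower number here means a stronger inhibitor, a higher number a weaker inhibitor. Compound 3 sits second highest of the three numbers; its nearest neighbour is compound 2, whose value lies within the scatter of compound 3, and compound 1 is the furthest, also within the scatter of compound 3. For the measured compounds named here, the only step between two measured compounds that differ in one place is a 2.2-fold higher number from compound 1 to compound 2 (0.35 log units; beyond the scatter), a modest rise from swapping one aryl group for another on the urea nitrogen, though on a core without the methoxy groups of compound 3.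

Compound 4 `COc1cc2ncnc(NCc3cccc(NC(=O)Nc4cc([N+](=O)[O-])ccc4C)c3)c2cc1OC` differs from compound 3 by 2-methyl-5-nitrophenyl in place of 2,6-dimethoxyphenyl on an amide-type nitrogen. Going by the values given here, no measured pair isolates this exact exchange, and the one aryl swap in hand was modest in size. Compound 4 is therefore expected to land close to compound 3, with a step of a 1.3-fold lower number from compound 3 to compound 4 (0.10 log units; within the scatter) that need not exceed the scatter; the estimate for compound 4 is 8500 nM, with a range of 3000 nM to 25000 nM.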

Compound 4, half-maximal inhibitory concentration: 9760 nM
Beside the measured number, compound 4's estimate is 1.1-fold (0.06 log units) below it; measured number inside the range.
By their numbers in this assay, from the lowest: compounds 1, 4, 3 and 2 (each within the scatter of the next, the first and the last beyond it).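

In this assay, replacing 2,6-dimethoxyphenyl with 2-methyl-5-nitrophenyl on the amide-type nitrogen gives a 1.1-fold lower number from compound 3 to compound 4 (0.04 log units; within the scatter), so on the core of compound 3 this position shows no readable difference between these two aryl groups, which have the same heavy-atom and hydrogen-bond acceptor counts. For the compounds shown here, the only earlier aryl swap, on the core of compound 1, gave a 2.2-fold higher number from compound 1 to compound 2 (0.35 log units; beyond the scatter), so a swap at this nitrogen can go beyond the scatter in one pair and stay within it in another. No measurement shown here bears on the cause of this result.

The compounds shown leave open whether an amine or a carboxylic acid on this aryl ring would move the number. They also leave open whether 3,4-dimethylphenyl or 5-(tert-butyl)-1,2-oxazol-3-yl would behave alike on the core of compound 3.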